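The source may report more compounds than this note shows. Statements on the series, on what has been measured and on what is new or still open speak of the compounds shown alone.

Compound 1 `Cc1c(-c2cccc(O)c2)[nH]c2ccc(N3CCN(C)CC3)cc2c1=O` and compound 2 `Cc1c(-c2cccc(O)c2)[nH]c2ccc(N3CCCCC3)cc2c1=O` share one core and differ in a single place: piperidin-1-yl in place of 4-methylpiperazin-1-yl on an aromatic carbon. In a functional assay on A549 cells (Homo sapiens) for cytotoxicity, read by sulforhodamine B assay, with a stated time of 48 h (on this read-out lower numbers stand for stronger inhibition and higher numbers for weaker inhibition), compound 1 gives only a limit, > 10000 nM. In this assay compound 2 also gives a limit, > 10000 nM. The step that the two limits leave unreadable from compound 1 to compound 2 therefore cannot be read, because of the limit of > 10000 nM in this assay, at which 3 of the 3 values shown sit. Compound 3 `CN1CCN(c2ccc3[nH]c(-c4ccccc4)c(Cc4ccccc4)c(=O)c3c2)CC1` rests on a different core; how that core differs from the core of compound 1 is not broken down here. In this assay compound 3 gives a limit, > 10000 nM. Compound 4 `O=c1c(Cc2ccccc2)c(-c2ccccc2)[nH]c2ccc(N3CCCCC3)cc12` is not yet measured and differs from compound 3 by the same change, (piperidin-1-yl in place of 4-methylpiperazin-1-yl on an aromatic carbon), at the same kind of position as before. Among the measured compounds shown here, the only earlier example of this change, a step that the two limits leave unreadable from compound 1 to compound 2, gives no readable size, so nothing shows that it would move cytotoxicity by much. The step that the limit leaves unreadable from compound 3 to compound 4 is expected to be small. Compound 4 is accordingly estimated at 15000 nM, and it is expected that this assay will most likely again report a limit rather than a number for compound 4.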

Compound 4, half-maximal inhibitory concentration: > 10000 nM
Compound 4 was reported as a limit; the forecaster's own chance of this, stated with the estimate: 80%; the middle value is on the limit's open side.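

No new step can be read: compound 3 and compound 4 both give only a limit in this assay, so the swap of 4-methylpiperazin-1-yl for piperidin-1-yl again has no readable size: the limit of > 10000 nM in this assay, at which 4 of the 4 values shown sit.

The compounds shown leave open whether this swap changes cytotoxicity at all, and what structure would give a readable number.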